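From dibutylamino to (dipentylamino)methyl on one chain carbon

The source may hold more compounds than are shown below. What is called first, only, known or untested is meant among the compounds shown, and "the series" means these compounds.

compound 1 `CCCOc1c(-c2cc(OC)c(OC)c(OC)c2)oc2ccccc2c1=O` gives 11800 nM here
compound 2 `CCN(CC)CCCCCOc1c(-c2cc(OC)c(OC)c(OC)c2)oc2ccccc2c1=O` gives 6600 nM here
compound 3 `CCCCN(CCCC)CCCOc1c(-c2cc(OC)c(OC)c(OC)c2)oc2ccccc2c1=O` gives 7100 nM here

These three values come from a functional assay on PC-3 cells (Homo sapiens) for antiproliferative activity, read by WST assay, with a stated time of 3 days (a higher number here means a weaker inhibitor, a lower number a stronger inhibitor), and the compounds share one core. Compound 3 at 7100 nM lies within the scatter of both others. Compound 4 `CCCCCN(CCCCC)CCCCOc1c(-c2cc(OC)c(OC)c(OC)c2)oc2ccccc2c1=O` has (dipentylamino)methyl in place of dibutylamino on a saturated chain carbon, three bonds along the chain from an oxygen on an aromatic ring. Three measured steps at that place bear on it: a 1.1-fold higher number from compound 2 to compound 3 (0.03 log units; within the scatter) as the closest swap, along with a 1.8-fold lower number from compound 1 to compound 2 (0.25 log units; within the scatter) and a 1.7-fold lower number from compound 1 to compound 3 (0.22 log units; within the scatter) as wider changes. All lie within the scatter, so no step beyond it is expected in this assay for this change. The estimated step is a 1.1-fold lower number from compound 3 to compound 4 (0.04 log units; within the scatter) and stays inside the scatter. Compound 4 is expected at 6500 nM with an estimated range from 2800 nM to 14000 nM in this measurement.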

Compound 4, half-maximal inhibitory concentration: 7900 nM
Beside the measured number, compound 4's estimate is 1.2-fold (0.08 log units) below it; low and high end bracket the measured number.
By their numbers in this assay, from the lowest: compounds 2, 3, 4 and 1 (each within the scatter of the next).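

In this assay the bulkier (dipentylamino)methyl group still gives only small steps: a 1.1-fold higher number from compound 3 to compound 4 (0.05 log units; within the scatter) and a 1.2-fold higher number from compound 2 to compound 4 (0.08 log units; within the scatter) and a 1.5-fold lower number from compound 1 to compound 4 (0.17 log units; within the scatter). Across these four compounds, then, enlarging the group on this saturated chain carbon leaves the number within the scatter, so a bigger amine group brings no measurable change here. No experimental evidence offers a reason for this flat result.

Still open, from the compounds shown here alone, is whether any group at this place can move the number beyond the scatter. A carboxylic acid or a morpholine ring on the same chain carbon would test that.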